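The compounds below may be only part of what the source reports. "The series", "measured", "known", "first", "only" and "open" are said of these compounds alone.

Three compounds share one core and differ in the group on an aromatic nitrogen: compound 1 `CC(C)Cn1nc(C(=O)N[C@H]2COc3ccccc3N(C)C2=S)nc1Cc1ccccc1`, compound 2 `CC(C)CCn1nc(C(=O)N[C@H]2COc3ccccc3N(C)C2=S)nc1Cc1ccccc1` and compound 3 `CN1C(=S)[C@@H](NC(=O)c2nc(Cc3ccccc3)n(C3CCCCC3)n2)COc2ccccc21`. In a toxicity assay on HT-29 cells (Homo sapiens) for cytotoxicity (a lower number here means that less compound is tolerated, a higher number that more compound is tolerated), compound 1 gives > 100000 nM, which is a limit and not a number. Compound 2 gives > 100000 nM, again a limit. Compound 3 gives > 100000 nM, also a limit, so no exact value is known for it.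

Compound 4 `CN1C(=S)[C@@H](NC(=O)c2nc(Cc3ccccc3)n(C3CCOCC3)n2)COc2ccccc21` keeps the rest of compound 3 and changes only the ring on that nitrogen: oxan-4-yl in place of cyclohexyl on an aromatic nitrogen. The ring stays six-membered, but one hetero atom enters and, with it, one hydrogen-bond acceptor.

The measured steps closest to this change sit on the same nitrogen: a step that the two limits leave unreadable from compound 1 to compound 2, a step that the two limits leave unreadable from compound 1 to compound 3 and a step that the two limits leave unreadable from compound 2 to compound 3. None has a readable size, and the whole set amounts to the limit of > 100000 nM in this assay, at which 3 of the 3 values shown sit. On these data alone, none of these steps brings a hetero atom into the group, so this swap itself is untested. Nothing measured therefore points to a step beyond the usual scatter in this assay, or to a direction. The estimated size is a number no higher from compound 3 to compound 4 (the limit leaves the size open), and another limit is the most likely report. For compound 4 the estimated value is 100000 nM, with an expected range from 50000 nM to 200000 nM.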

Compound 4, half-maximal cytotoxic concentration: > 100000 nM
Compound 4 was reported as a limit (the forecaster's own chance of this, stated with the estimate: 90%); the middle value sits exactly at the limit.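

Compound 4, like compound 1, compound 2 and compound 3, is reported only as a limit, so none of its steps to those three compounds can be read, and all four values sit at one ceiling: the limit of > 100000 nM in this assay, at which 4 of the 4 values shown sit. The compounds shown leave open whether any group on that aromatic nitrogen changes the result in this assay, and in which direction.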